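The source may hold more compounds than are shown below. What is called first, only, known or untested is meant among the compounds shown, and "the series" means these compounds.

Measured so far in an assay on isolated protein for inhibition of Amine oxidase [flavin-containing] A (Homo sapiens), read by fluorescence, with stated times of 15 min and 20 min; a lower number here means a stronger inhibitor, a higher number a weaker inhibitor:
compound 1, `O=C(CN1CCCCC1)N1N=C(c2ccc(F)cc2)CC1c1cc(Cl)ccc1O`: 3720 nM
compound 2, `O=C(CN1CCNCC1)N1N=C(c2ccc(F)cc2)CC1c1cc(Cl)ccc1O`: 2400 nM
compound 3, `CC1=NN(C(=O)CN2CCCCC2)C(c2cc(Br)cc(Br)c2O)C1`: 7800 nM

Compounds 1 and 2 share a core and differ in one place: piperazin-1-yl in place of piperidin-1-yl on a saturated chain carbon bound to a carbonyl carbon. In this assay that change gave a 1.6-fold lower number from compound 1 to compound 2 (0.19 log units; within the scatter), a step within the scatter of repeated measurements. Compound 3 carries a different core; the difference between the two cores is not broken down here. Of the three numbers, that of compound 3 is the highest, and its steps to compound 1 and to compound 2 are both beyond the scatter.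

Compound 4, `CC1=NN(C(=O)CN2CCNCC2)C(c2cc(Br)cc(Br)c2O)C1`, is not yet measured. It stands to compound 3 as compound 2 stands to compound 1: piperazin-1-yl in place of piperidin-1-yl on a saturated chain carbon bound to a carbonyl carbon. The place is the same in both pairs, so this is the same change carried onto a second core. For the measured compounds named here, the only precedent is the single pair already measured; nothing shows how the change behaves on the core of compound 3. For compound 4 the expected step is a 1.6-fold lower number from compound 3 to compound 4 (0.19 log units; within the scatter), kept modest because a 1.6-fold lower number from compound 1 to compound 2 (0.19 log units; within the scatter) was itself modest. The estimate for compound 4 in this assay is 5000 nM, with a likely range from 2000 nM to 12000 nM.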

Compound 4, half-maximal inhibitory concentration: 2000 nM
Estimate against measurement, compound 4: 2.5-fold (0.40 log units) above, and the stated range covers the measured number.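

In this assay, piperazin-1-yl in place of piperidin-1-yl on the core of compound 3 gave a 3.9-fold lower number from compound 3 to compound 4 (0.59 log units; beyond the scatter). For the compounds shown here, although only this new step lies beyond the scatter, the steps on the two cores cannot be told apart: the same change on two cores in this assay, a 1.6-fold lower number (0.19 log units; within the scatter) from compound 1 to compound 2 and a 3.9-fold lower number (0.59 log units; beyond the scatter) from compound 3 to compound 4, 2.5-fold (0.40 log units) apart, within the scatter of two such steps. Going by these compounds alone, the result therefore gives no sign that the outcome of this change depends on the core, but two pairs fix no size for the step and do not show how it would behave on any further core.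

Still open, on these data alone, is how morpholin-4-yl, 4-methylpiperazin-1-yl or a dimethylamino group would compare with piperazin-1-yl in the same place, and whether a longer chain to the carbonyl carbon would preserve the number seen for compound 4. Also open, as far as these compounds go, is which part of the difference between the core of compound 1 and the core of compound 3 goes with any difference between the two steps.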